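From compound 3 to compound 4: one group swapped

The source may hold more compounds than are shown below. What is called first, only, known or untested is meant among the compounds shown, and "the series" means these compounds.

compound 1 `O=C(NCc1ccc(S(=O)(=O)c2ccccc2)cc1)c1nc2cnccc2[nH]1`: 5400 nM
compound 2 `O=C(NCc1ccc(S(=O)(=O)c2ccccc2)cc1)c1cc2ccncc2s1`: 14 nM
compound 3 `O=C(NCc1ccc(S(=O)(=O)c2ccccc2)cc1)c1ccc2nccn2c1`: 13 nM

In a functional assay on A2780 cells (Homo sapiens) for inhibition, read by sulforhodamine B assay, with a stated time of 72 h (a lower number here means a stronger inhibitor, a higher number a weaker inhibitor), compound 3 (13 nM) sits together with compound 2 at the strong end of this small set, far from compound 1. Compound 4 (`O=C(NCc1ccc(S(=O)(=O)c2ccccc2)cc1)c1ccc2nncn2c1`) keeps the rest of compound 3 and alters only the group on the carbonyl carbon: a group of 9 heavy atoms (6 carbon, 3 nitrogen; one five-membered aromatic ring with 3 hetero atoms, one six-membered aromatic ring with 1 hetero atom) in place of a group of 9 heavy atoms (7 carbon, 2 nitrogen; one five-membered aromatic ring with 2 hetero atoms, one six-membered aromatic ring with 1 hetero atom), on a carbonyl carbon.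

Among the measured compounds shown here, two measured steps bear on this change. One is a 1.1-fold lower number from compound 2 to compound 3 (0.03 log units; within the scatter), which shows that one swap of this group cost nothing measurable. The other is a 420-fold lower number from compound 1 to compound 3 (2.62 log units; beyond the scatter), and the group of compound 1 has the same count of 6 carbon and 3 nitrogen as the entering group. Its five-membered ring differs, however, so neither step is the same change. A moderate loss is therefore expected, well short of the large step seen with compound 1. The expected change is a 4.6-fold higher number from compound 3 to compound 4 (0.66 log units; beyond the scatter). Compound 4 is estimated at 60 nM, with an expected range of 13 nM to 400 nM.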

Compound 4, half-maximal inhibitory concentration: > 10000 nM
Compound 4 ended at the assay's limit (the forecaster's own chance of this, stated with the estimate: 3%); at least 160-fold (2.22 log units) between middle value and limit.
By their numbers in this assay, from the lowest: compounds 3 and 2 (each within the scatter of the next); then compound 1. At a limit, above all of these: compound 4.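

Compound 4's reading in this assay is a limit of the assay and not a number: the limit of > 10000 nM in this assay, at which 1 of the 4 values shown sits. Even so, an at least 760-fold higher number from compound 3 to compound 4 (2.88 log units; beyond the scatter) shows that on this carbonyl carbon, going from a group of 7 carbon and 2 nitrogen to one of 6 carbon and 3 nitrogen is enough for a large loss, whereas the earlier swap between compounds 2 and 3 changed nothing measurable. The same loss appears in an at least 710-fold higher number from compound 2 to compound 4 (2.85 log units; beyond the scatter), while an at least 1.8-fold higher number from compound 1 to compound 4 (0.26 log units; that floor lies within the scatter) has a floor within the scatter, so these two groups of 6 carbon and 3 nitrogen cannot be told apart here.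

How far past its limit compound 4 lies stays unknown, and the compounds shown give no reason for the loss. Going by these compounds, whether a methyl group added to the five-membered aromatic ring with 3 hetero atoms would recover the lost strength also stays open.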